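Replacing butyl with but-1-en-1-yl on the side chain

This account rests on a few compounds, and the source may have more. Where it says the series, first, only, none or still open, it means among the compounds named here.

Measured compounds:
compound 1, `CCCC[C@H](CC)C[C@]1(CC)C=C(CC)/C(=C/C(=O)OC)O1`, 4200 nM
compound 2, `CCCCC(C)Cc1cc(CC)c(CC(=O)O)o1`, > 100000 nM

Within the data shown here, compound 1 is the only compound here with a numerical value. In a functional assay on HeLa cells (Homo sapiens) for cytotoxicity, read by MTT assay, with a stated time of 72 h (a higher number here means a weaker inhibitor, a lower number a stronger inhibitor), compound 1 gives 4200 nM. Compound 2, a different kind of compound with a carboxylic acid instead of the methyl ester, gives only a limit in this assay, > 100000 nM; the limit is the limit of > 100000 nM in this assay, at which 1 of the 2 values shown sits, and no number is known for it. Compound 3, `CC/C=C/[C@H](CC)C[C@]1(CC)C=C(CC)/C(=C/C(=O)OC)O1`, has not yet been measured. It differs from compound 1 in one place only: but-1-en-1-yl in place of butyl on a saturated chain carbon bound to two saturated chain carbons. A change of this kind on a saturated chain, well away from the unsaturated ester part, is expected to shift the cytotoxicity value little, with no direction beyond the usual scatter. The step from compound 1 to compound 3 is therefore estimated as a 1.1-fold lower number from compound 1 to compound 3 (0.02 log units; within the scatter), and compound 3 is expected to give about 4000 nM in this assay, within a range from 1500 nM to 12000 nM.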

Compound 3, half-maximal inhibitory concentration: 2600 nM
Compound 3: middle estimate off by 1.5-fold (0.19 log units), on the high side; the measured number falls inside the stated range.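

Putting but-1-en-1-yl in place of butyl on a saturated chain carbon bound to two saturated chain carbons gives a 1.6-fold lower number from compound 1 to compound 3 (0.21 log units; within the scatter) in this assay. Among these compounds, this pair is the first direct look at this part of the side chain, and it shows that a double bond can enter the chain there without a change beyond the scatter. The compounds shown offer nothing that explains the size of this step.

Going by these compounds, whether a longer chain such as hexyl, an amine or a hydroxyl group at this place would move the number remains open. So does the effect of the cis form of the same double bond, since this single pair carries only one form.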